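Amide Replacement on the Indoline-Bearing Carbamate Series

A few compounds are considered here, and "the series" means these few. Any claim that something is new, unique, unknown or untested is made for them only; others in the source may bear on it.

Of the compounds shown here, three have been measured in an assay on isolated protein for inhibition of cathepsin S (Homo sapiens); on this read-out lower numbers stand for stronger inhibition and higher numbers for weaker inhibition. Compound 1 `CC(C)[C@@H](CNc1ccc(OC(F)(F)F)cc1)NC(=O)O[C@@H](CC1CCCCC1)C(=O)N1CCOCC1` gives 8 nM, compound 2 `C[C@@H](CN1c2ccc(F)cc2CC1(C)C)NC(=O)O[C@@H](CC1CCCCC1)C(=O)N1CCOCC1` gives 80 nM, and compound 3 `C[C@@H](CN1CC(C)(C)c2cc(F)ccc21)NC(=O)O[C@@H](CC1CCCCC1)C(=O)N(C)C` gives 227 nM. Compound 3 thus stands with the highest number of the three, and its distance from both compound 2 and compound 1 lies beyond the usual scatter. Compound 2 and compound 3 differ in more than one place, so their two values can only be set side by side, not read as a single step.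

Compound 4 `C[C@@H](CN1CC(C)(C)c2cc(F)ccc21)NC(=O)O[C@@H](CC1CCCCC1)C(=O)N1CCN(S(C)(=O)=O)CC1` has not yet been measured. It differs from compound 3 in one place: 4-(methylsulfonyl)piperazin-1-yl in place of dimethylamino on a carbonyl carbon. The shared carbamate and the fluorinated indoline part of compound 3 are kept unchanged.

Going by the values given here, with no single-point step between measured compounds to lean on, the expectation for this change rests loosely on compound 2, whose cyclic amide pairs with 80 nM. The step from compound 3 to compound 4 is expected to be a moderate move toward a lower number, a 2.1-fold lower number from compound 3 to compound 4 (0.31 log units; beyond the scatter), though a result within the scatter would not surprise. Compound 4 is therefore estimated at 110 nM, with a plausible range from 35 nM to 350 nM.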

Compound 4, inhibition constant: 1080 nM
Estimate against measurement, compound 4: 9.8-fold (0.99 log units) below; the measured number lies above the stated range.
By their numbers in this assay, from the lowest: compound 1; then compound 2; then compound 3; then compound 4.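

In this assay, going by these compounds alone, the exchange of dimethylamino for 4-(methylsulfonyl)piperazin-1-yl on the carbonyl carbon gives a 4.8-fold higher number from compound 3 to compound 4 (0.68 log units; beyond the scatter) and so provides the first reading of this position in which only one place differs. With the shared carbamate and the fluorinated indoline part held constant, the group on this carbonyl alone moves the number toward weaker inhibition, and this entering group, with one six-membered non-aromatic ring, 10 heavy atoms in place of 3 and 2 hydrogen-bond acceptors, does not improve on dimethylamino. No measurement at hand bears on why the number rises with this exchange.

The single step bundles the ring and the methylsulfonyl group together, so the compounds shown leave open which part of the entering group goes with the higher number, and a piperidine or a 4-acetylpiperazin-1-yl group on the same carbonyl would help to separate the two. Also open, from the compounds shown here alone, is whether a smaller amine such as azetidine or pyrrolidine on this carbonyl would read differently from dimethylamino, with the rest of compound 3 kept as it is.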